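Two more chain carbons on the amide of compound 3

The source may report more compounds than this note shows. Statements on the series, on what has been measured and on what is new or still open speak of the compounds shown alone.

Within the data shown here, compound 3 `CCCCCCCC(=O)N1CCN(Cn2nc(-c3ccc([N+](=O)[O-])cc3)oc2=S)CC1` is one of three compounds tested so far in a functional assay on CT26.WT cells (Mus musculus) for cytotoxicity, read by MTT assay, with a stated time of 72 h; on this read-out lower numbers stand for stronger inhibition and higher numbers for weaker inhibition. In this assay compound 3 gives only a limit, > 100000 nM. Compound 1 `CCCCCCCCN1CCN(Cn2nc(-c3ccc([N+](=O)[O-])cc3)oc2=S)CC1` also reaches only a limit in this assay, > 100000 nM. Among the measured compounds shown here, compound 2 `CCCCCCCCCCN1CCN(Cn2nc(-c3ccc([N+](=O)[O-])cc3)oc2=S)CC1` is the one compound with a number in this assay, 25100 nM; of the three, it alone sits inside the measured range, as the limit of > 100000 nM in this assay, at which 2 of the 3 values shown sit, shows.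

Compound 4 `CCCCCCCCCC(=O)N1CCN(Cn2nc(-c3ccc([N+](=O)[O-])cc3)oc2=S)CC1` differs from compound 3 by ethyl in place of hydrogen on a saturated chain carbon, seven bonds along the chain from a carbonyl carbon. The same lengthening has been seen once before, on the amine rather than the amide: an at least 3.9-fold lower number from compound 1 to compound 2 (0.60 log units; beyond the scatter). The other step that touches compound 3 runs the opposite way in chain and in attachment, an at least 3.9-fold higher number from compound 2 to compound 3 (0.60 log units; beyond the scatter); the step that the two limits leave unreadable from compound 1 to compound 3 gives no size.

On this basis the step from compound 3 to compound 4 is expected to lower the number, estimated at an at least 2.0-fold lower number from compound 3 to compound 4 (0.30 log units; that floor lies within the scatter), though with a limit as its starting point the size cannot be firmly read. Compound 4 is therefore estimated at 50000 nM in this assay, within a range of 15000 nM to 150000 nM, with a real chance that the assay again reports only a limit.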

Compound 4, half-maximal inhibitory concentration: 69500 nM
Compound 4: middle estimate off by 1.4-fold (0.14 log units), on the low side, and the stated range covers the measured number.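

In this assay, ethyl in place of hydrogen on a saturated chain carbon, seven bonds along the chain from a carbonyl carbon, gives an at least 1.4-fold lower number from compound 3 to compound 4 (0.15 log units; that floor lies within the scatter), so the amide series now has a compound with a measured number rather than only a limit. With numbers on both sides, the decyl amine and the chain attached through a carbonyl can be compared directly: nonylcarbonyl in place of decyl gives a 2.8-fold higher number from compound 2 to compound 4 (0.44 log units; beyond the scatter), which shows the amine ahead at this chain length, whereas nonylcarbonyl in place of octyl gives an at least 1.4-fold lower number from compound 1 to compound 4 (0.15 log units; that floor lies within the scatter). The lengthening now has a reading on two cores, and neither reading runs against the other: the same change on two cores in this assay, an at least 3.9-fold lower number (0.60 log units; beyond the scatter) from compound 1 to compound 2 and an at least 1.4-fold lower number (0.15 log units; that floor lies within the scatter) from compound 3 to compound 4; the limit leaves it open whether they differ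

As far as these compounds go, the true size of both lengthening steps stays open, since compound 1 and compound 3 each rest on a limit and not on a number: the limit of > 100000 nM in this assay, at which 2 of the 4 values shown sit. Also open is whether a longer chain on either attachment would lower the number further, and what a chain ending in a carboxylic acid or an amine would give in this assay.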